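Swapping the aryl group in a tested antiproliferative series

This account rests on a few compounds, and the source may have more. Where it says the series, first, only, none or still open, it means among the compounds named here.

Compound 2 `COc1ccc(-c2nc(C)c(C(=O)CSc3nc(-c4ccc(Cl)c(Cl)c4)c(C#N)c(=O)[nH]3)s2)cc1` was tested in a functional assay on U-87MG ATCC cells for antiproliferative activity against U-87 MG (Homo sapiens), read by MTT assay, with a stated time of 48 h, tested at 5 uM (a higher number here means a weaker effect of the compound at the concentration tested, a lower number a stronger effect), and gave 101%. Within the data shown here, it stands highest of the two numbers measured so far; its nearest neighbour is compound 1 `COc1ccc(-c2nc(C)c(C(=O)CSc3nc(-c4ccc(OC)c(OC)c4)c(C#N)c(=O)[nH]3)s2)cc1`, which in this assay gave 81.2%. Among the measured compounds shown here, the one step measured between these two, a number 19.8 percentage points higher from compound 1 to compound 2 (beyond the scatter), was 3,4-dichlorophenyl in place of 3,4-dimethoxyphenyl on an aromatic carbon.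

The next compound, compound 3 `COc1ccc(-c2nc(C)c(C(=O)CSc3nc(-c4ccccc4)c(C#N)c(=O)[nH]3)s2)cc1`, differs from compound 2 by phenyl in place of 3,4-dichlorophenyl on an aromatic carbon. This change sits at the same aromatic carbon as the measured step, so that step is the only one that bears on it, and it was modest. Nothing measured shows what removing the two chlorines from that ring does, so the direction of the step is uncertain and is expected to stay close to the scatter, perhaps slightly downward. Compound 3 is therefore expected to give 92% in this assay, within 75% to 108%, meaning an estimated step of a number 9 percentage points lower from compound 2 to compound 3 (within the scatter).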

Compound 3, a percentage reported as activity, at one concentration (the size of the read-out at that concentration, not a potency): 99%
Estimate against measurement, compound 3: 7 percentage points below; low and high end bracket the measured number.
By their numbers in this assay, from the lowest: compound 1; then compounds 3 and 2 (each within the scatter of the next).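

In this assay, the position tolerates losing both chlorines without a readable effect (a number 2 percentage points lower from compound 2 to compound 3 (within the scatter)), so 3,4-dichlorophenyl and phenyl cannot be told apart here. The comparison with 3,4-dimethoxyphenyl now rests on two aryl groups rather than one: phenyl also sits apart from it (a number 17.8 percentage points higher from compound 1 to compound 3 (beyond the scatter)), which leaves compound 1, at 81.2%, as the only one of the three whose number stands clearly apart from the others. Among these compounds, then, the chlorines themselves make no visible difference, and what separates the series at this carbon is the presence of 3,4-dimethoxyphenyl; nothing available explains this result.

The compounds shown leave open whether a single methoxy group, as in 4-methoxyphenyl, would be enough to match compound 1, or whether both are needed. They also leave open whether a different group on that phenyl ring, such as an amine or a carboxylic acid, or a longer alkoxy chain in place of the methoxy groups, would take the number in this assay lower than compound 1 does.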